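Trading a butyl chain for a carboxyethyl group

This account rests on a few compounds, and the source may have more. Where it says the series, first, only, none or still open, it means among the compounds named here.

Compound 1 `CCCCc1nc2cc(OC3CCN(C(C)=N)CC3)ccc2n1Cc1ccc2ccc(C(=N)N)cc2c1` and compound 2 `CC(=N)N1CCC(Oc2ccc3nc(C)n(Cc4ccc5ccc(C(=N)N)cc5c4)c3c2)CC1` share one core and differ only in the chain on it. In an assay on isolated protein for inhibition of serine protease 1 (Bos taurus) (a higher number here means a weaker inhibitor, a lower number a stronger inhibitor), compound 1 gives 14 nM, and compound 2 gives 18 nM; the two numbers sit within the usual scatter of each other, so neither stands apart. Compound 3 `CC(=N)N1CCC(Oc2ccc3c(c2)nc(CCC(=O)O)n3Cc2ccc3ccc(C(=N)N)cc3c2)CC1` has not yet been measured in this assay. It differs from compound 1 by carboxy in place of ethyl on a saturated chain carbon, two bonds along the chain from an aromatic carbon. Within the data shown here, no step between measured compounds covers such a change, so the expected step from compound 1 to compound 3 is a 1.8-fold higher number from compound 1 to compound 3 (0.25 log units; within the scatter), a small shift that may not exceed the scatter. Compound 3 is therefore estimated at 25 nM, within 8 nM to 80 nM.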

Compound 3, inhibition constant: 14 nM
Estimate against measurement, compound 3: 1.8-fold (0.25 log units) above; the measured number falls inside the stated range.
By their numbers in this assay, from the lowest: compounds 1, 3 and 2 (each within the scatter of the next).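

In this assay, putting 2-carboxyethyl in place of butyl on the shared core gives no change at the digits printed from compound 1 to compound 3 (within the scatter), and this is the only step shown at this position. The chain here can therefore end in carboxy rather than ethyl and the number holds, which compound 1 and compound 2 alone could not show. Nothing measured here explains why the number holds. Still open, from the compounds shown here alone, is whether an amine at the end of this chain, or a longer chain ending in carboxy, would hold the number as well.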